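Swapping a Sulfonamide for a Pyrazole on a Biaryl

The source may report more compounds than this note shows. Statements on the series, on what has been measured and on what is new or still open speak of the compounds shown alone.

Measured compounds:
Compound 1, `CNS(=O)(=O)c1ccc(-c2cnc(N)c(-c3ccc(OC)nc3)c2)cc1`, 2.2
Compound 2, `COc1ccc(-c2cc(-c3ccc(S(C)(=O)=O)c(F)c3)cnc2N)cn1`, 2.5
Compound 3, `COc1ccc(-c2cc(-c3ccc(S(C)(=O)=O)cc3C(F)(F)F)cnc2N)cn1`, 2.7

Of the compounds shown here, three sharing one core have been measured in a physicochemical assay for lipophilicity, at pH 7.4; on this read-out higher numbers stand for higher lipophilicity and lower numbers for lower lipophilicity. In this assay compound 1 gives 2.2, compound 2 gives 2.5 and compound 3 gives 2.7. Compound 1 and compound 2 lie within the usual scatter of each other, so no order between them can be read from these numbers. Compound 3 stands beyond the scatter from compound 1, with the higher number, and is the only one of the three that does so.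

Compound 4, `COc1ccc(-c2cc(-c3ccc(-n4cccn4)cc3)cnc2N)cn1`, has not yet been measured in this assay. It differs from compound 1 in one place: 1H-pyrazol-1-yl in place of methylsulfamoyl on an aromatic carbon. For the measured compounds named here, no pair among the measured compounds differs by this same change, so there is no measured step to lean on; the expectation rests on the structural change alone. A methylsulfamoyl group with its hydrogen-bond donor leaves and a 1H-pyrazol-1-yl with no donor enters, which is expected to move the number upward by a clear amount in this assay. The expected step is a number 1.00 log units higher from compound 1 to compound 4 (beyond the scatter), beyond the scatter. Compound 4 is therefore estimated at 3.2, with a likely range from 2.7 to 3.7.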

Compound 4, distribution coefficient: 3.1
Compound 4: the middle estimate sits 0.10 log units above what was measured; the range from low to high includes it.
By their numbers in this assay, from the lowest: compounds 1, 2 and 3 (each within the scatter of the next, the first and the last beyond it); then compound 4.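

In this assay, 1H-pyrazol-1-yl in place of methylsulfamoyl on an aromatic carbon gives a number 0.90 log units higher from compound 1 to compound 4 (beyond the scatter) and is the only step shown between two compounds that differ in one place. This position, on a six-membered aromatic ring of carbon only and para to a large group, thus responds to this exchange by more than the scatter, even though both groups carry 5 heavy atoms and 2 hydrogen-bond acceptors and only methylsulfamoyl carries a hydrogen-bond donor. No measurement shown here accounts for the step, so it cannot be assigned to any one of the differences between the two groups.

The compounds shown leave open where other groups at this position, such as a primary amide, a carboxylic acid or a morpholine ring, would fall relative to compound 1 and compound 4. They also leave open whether the same exchange gives a step of this size when other parts of the shared core change, as this single pair is the only one that carries it.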